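Methoxy replaced on the shared core: compound 4

The source may hold more compounds than are shown below. What is called first, only, known or untested is meant among the compounds shown, and "the series" means these compounds.

Measured in an ADME assay on KB cells (Homo sapiens) for cytotoxicity, with a stated time of 48 h; on this read-out lower numbers stand for stronger inhibition and higher numbers for weaker inhibition:
compound 1 `C=C1[C@H](C)CCC[C@]1(C)CC/C(C)=C/CC1=C(O)C(=O)C=C(N[C@H](C(=O)O)[C@@H](C)O)C1=O`: > 10 ug/mL (a limit)
compound 2 `C=C1[C@H](C)CCC[C@]1(C)CC/C(C)=C/CC1=C(O)C(=O)C=C(N[C@@H](C(=O)O)[C@@H](C)O)C1=O`: > 10 ug/mL (a limit)
compound 3 `C=C1[C@H](C)CCC[C@]1(C)CC/C(C)=C/CC1=C(O)C(=O)C=C(OC)C1=O`: > 10 ug/mL (a limit)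

In this assay compound 3 gives > 10 ug/mL, which is a limit and not a number. For the measured compounds named here, the series so far sits at the limit of > 10 ug/mL in this assay, at which 3 of the 3 values shown sit, so no order can be drawn among the three compounds.

Compound 4 `C=C1[C@H](C)CCC[C@]1(C)CC/C(C)=C/CC1=C(O)C(=O)C=C(N[C@@H](CO)C(=O)O)C1=O` carries (1-carboxy-2-hydroxyethyl)amino in place of methoxy on a double-bonded ring carbon.

Going by the values given here, three measured steps bear on this change: a step that the two limits leave unreadable from compound 1 to compound 3, a step that the two limits leave unreadable from compound 2 to compound 3 and a step that the two limits leave unreadable from compound 1 to compound 2. None of them has a readable size. The first two exchange methoxy and (1-carboxy-2-hydroxypropyl)amino on that same carbon, while the third concerns configuration alone (the fact that compounds 1 and 2 differ only in the configuration as drawn).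

No readable shift in either direction is therefore expected in this assay, and another limit is the likeliest report. The expected change is a step that the limit leaves unreadable from compound 3 to compound 4. The estimate for compound 4 is 20 ug/mL. The expected range for this compound runs from 10 ug/mL to 40 ug/mL.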

Compound 4, half-maximal inhibitory concentration: > 10 ug/mL
Compound 4 gave a limit, no number; the forecaster's own chance of this, stated with the estimate: 85%; the middle value does not contradict the limit.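

In this assay compound 4 gives > 10 ug/mL, a limit and not a number, so no step linking compound 4 to compound 1, compound 2 or compound 3 can be read: the limit of > 10 ug/mL in this assay, at which 4 of the 4 values shown sit.

The compounds shown leave open whether methoxy, (1-carboxy-2-hydroxyethyl)amino and (1-carboxy-2-hydroxypropyl)amino on the double-bonded ring carbon differ at all in this assay.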